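The compounds below may be only part of what the source reports. "The series", "measured", "known", "first", "only" and "open" are said of these compounds alone.

Going by the values given here, compound 1, `Cc1nn(C(C)(C)C)c2nc(C3CC3)c(/C=C/[C@@H](O)C[C@@H](O)CC(=O)O)c(-c3ccc(F)cc3)c12`, is the weaker of the two compounds measured so far: in an in vivo functional assay on the whole organism for inhibition of 3-hydroxy-3-methylglutaryl-coenzyme A reductase (Rattus norvegicus), at a dose of 2 mg/kg by the oral route (on this read-out higher numbers stand for a stronger effect at the one dose given and lower numbers for a weaker effect), compound 1 gives 72.2%, the lowest of the two numbers in hand. Among the compounds with values here, its only measured neighbour is compound 2, `Cc1nn(C(C)(C)C)c2nc(C(C)C)c(/C=C/[C@@H](O)C[C@@H](O)CC(=O)O)c(-c3ccc(F)cc3)c12`, which in this assay gives 86%; the step of a number 13.8 percentage points higher from compound 1 to compound 2 (beyond the scatter), isopropyl in place of cyclopropyl on an aromatic carbon, lies beyond the scatter. Compound 3, `Cc1nn(C)c2nc(C3CC3)c(/C=C/[C@@H](O)C[C@@H](O)CC(=O)O)c(-c3ccc(F)cc3)c12`, differs from compound 1 at a different place: methyl in place of tert-butyl on an aromatic nitrogen. Within the data shown here, no measured step touches this aromatic nitrogen, so the one known step, which concerns the substituent on the aromatic carbon, gives no direct guidance here. In the absence of such a step, the account expects the change a number 10.2 percentage points lower from compound 1 to compound 3 (beyond the scatter) to stay within the scatter or to be at most a modest fall. Compound 3 is therefore estimated at 62%, within a range from 38% to 82%.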

Compound 3, a percentage reported as inhibition, in the whole organism at one dose (the size of the read-out at that dose, not a potency): 74.3%
Compound 3: middle estimate off by 12.3 percentage points, on the low side, and the stated range covers the measured number.
By their numbers in this assay, from the lowest: compounds 1 and 3 (each within the scatter of the next); then compound 2.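

Going by these compounds alone, the aromatic nitrogen, which no earlier step had touched, proves insensitive to this change: replacing tert-butyl (4 heavy atoms) with methyl (1 heavy atom) gives a number 2.1 percentage points higher from compound 1 to compound 3 (within the scatter) in this assay at the one oral dose given. This contrasts with the only earlier step, at the aromatic carbon, which is a number 13.8 percentage points higher from compound 1 to compound 2 (beyond the scatter) and lies beyond the scatter, so among these compounds only that carbon substituent has moved the read-out. Nothing available bears on the reason for this result.

From the compounds shown here alone, it remains open whether an ethyl or isopropyl group, or a phenyl ring or hydroxyethyl chain, on this nitrogen would read alike. Also open, going by these compounds, is whether methyl here would behave the same with isopropyl, rather than cyclopropyl, on the aromatic carbon.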